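Swapping furan-2-yl for pyridin-4-yl on a cytotoxic scaffold

The source may report more compounds than this note shows. Statements on the series, on what has been measured and on what is new or still open speak of the compounds shown alone.

Compound 2 `CC1(c2ccc(-c3ccco3)cc2)CC(S(=O)(=O)c2ccc(F)cc2)=C(c2ccc(/C(N)=N\O)cc2)O1` gives the lowest number of the three measured compounds in an ADME assay on J774.A1 cells (Mus musculus) for cytotoxicity, read by MTT assay, with a stated time of 72 h (a lower number here means that less compound is tolerated, a higher number that more compound is tolerated), namely 4560 nM. The nearest measured neighbour is compound 3 `CC1(Cc2ccccc2)CC(S(=O)(=O)c2ccccc2C(F)(F)F)=C(c2ccc(/C(N)=N\O)cc2)O1`, which in this assay gives 23500 nM, and the furthest is compound 1 `CC1(Cc2ccccc2)CC(S(=O)(=O)c2cccc(F)c2)=C(c2ccc(/C(N)=N\O)cc2)O1`, which gives 28300 nM; both of those gaps lie beyond the scatter. Among the compounds with values here, compounds 1 and 3 carry a benzyl group on the shared core in place of the 4-(furan-2-yl)phenyl group of compound 2, and also differ from it in the arene on the sulfonyl sulfur, so no single step links either of them to compound 2.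

Compound 4 `CC1(c2ccc(-c3ccncc3)cc2)CC(S(=O)(=O)c2ccc(F)cc2)=C(c2ccc(/C(N)=N\O)cc2)O1` differs from compound 2 by pyridin-4-yl in place of furan-2-yl on an aromatic carbon. Within the data shown here, the only measured single step, a 1.2-fold lower number from compound 1 to compound 3 (0.08 log units; within the scatter), concerns the sulfonyl arene and lies within the scatter; it does not touch the position that changes here. Among the measured compounds shown here, no measured step bears on the exchange of one aromatic ring for another at this place. With nothing in the data pointing either way, the step from compound 2 to compound 4 is expected to stay within the scatter, a 1.1-fold higher number from compound 2 to compound 4 (0.04 log units; within the scatter). Compound 4 is therefore estimated at 5000 nM in this assay, with a range from 2000 nM to 15000 nM.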

Compound 4, half-maximal cytotoxic concentration: 6750 nM
Compound 4: middle estimate off by 1.4-fold (0.13 log units), on the low side; the range from low to high includes it.
By their numbers in this assay, from the lowest: compounds 2 and 4 (each within the scatter of the next); then compounds 3 and 1 (each within the scatter of the next).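

At this place, an aromatic carbon of a six-membered aromatic ring of carbon only, para to a large group, this assay now has its first measured step, and it reads a 1.5-fold higher number from compound 2 to compound 4 (0.17 log units; within the scatter). Within the data shown here, exchanging a five-membered aromatic ring with one oxygen for a six-membered aromatic ring with one nitrogen therefore leaves the two compounds within the scatter of each other, so this assay does not separate furan-2-yl from pyridin-4-yl here, whereas the earlier compounds offered no step at this place at all. Nothing measured here gives a reason for this result.

Both groups seen at this place are single aromatic rings, so the compounds shown leave open how the number would respond to a quite different group there, such as an amine, a carboxylic acid or a longer alkyl chain. They also leave open whether the same exchange of rings would read alike with 3-fluorophenyl or 2-(trifluoromethyl)phenyl on the sulfonyl sulfur.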